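This account rests on a few compounds, and the source may have more. Where it says the series, first, only, none or still open, it means among the compounds named here.

Measured in a functional assay on KB cells (Homo sapiens) for inhibition, read by sulforhodamine B assay; on this read-out lower numbers stand for stronger inhibition of growth and higher numbers for weaker inhibition of growth:
- compound 1 `COc1ccc(-c2ccc(-c3ccc(-c4nc5cc(C)ccc5[nH]4)cc3)cc2)cc1OC`: 2190 nM
- compound 2 `Oc1cccc2[nH]c(-c3ccc(-c4ccc(-c5ccc(OC(F)(F)F)cc5)cc4)cc3)nc12`: 3310 nM
- compound 3 `Oc1ccc(-c2ccc(-c3ccc(-c4nc5c(O)cccc5[nH]4)cc3)cc2)cc1`: 3190 nM

In this assay, compound 3 gives 3190 nM. This lies within the usual scatter of both other measurements, so the three compounds cannot be ranked on these numbers.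

The next compound, compound 4 `COc1ccc(-c2ccc(-c3ccc(-c4nc5c(O)cccc5[nH]4)cc3)cc2)cc1OC`, keeps the core of compound 3 and changes one group: 3,4-dimethoxyphenyl in place of 4-hydroxyphenyl on an aromatic carbon. For the measured compounds named here, one measured step bears on this place: a 1.0-fold lower number from compound 2 to compound 3 (0.02 log units; within the scatter). That exchange of hydrogen for trifluoromethyl on an oxygen on an aromatic ring left the number within the scatter. Compound 1 also offers a guide, since it already carries the 3,4-dimethoxyphenyl group, although its core is substituted differently. Compound 1 gives 2190 nM, again within the scatter of compound 3.

Going by the values given here, no measured pair isolates the exact exchange, so the evidence is indirect. Even so, nothing measured so far points to a step beyond the scatter, and none is expected here, with at most a slight lean towards the value of compound 1. The estimate amounts to a 1.2-fold lower number from compound 3 to compound 4 (0.09 log units; within the scatter), which is an expected step and not a measured one. For compound 4 the expected value is 2600 nM, with an estimated range from 1200 nM to 5500 nM.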

Compound 4, concentration for 50% growth inhibition: 2710 nM
For compound 4 the middle estimate is 1.0-fold (0.02 log units) below the measured one, and the stated range covers the measured number.
By their numbers in this assay, from the lowest: compounds 1, 4, 3 and 2 (each within the scatter of the next).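

In this assay, the exchange at this position gives a 1.2-fold lower number from compound 3 to compound 4 (0.07 log units; within the scatter), so 3,4-dimethoxyphenyl in place of 4-hydroxyphenyl does not separate the two compounds, even though the entering group has no hydrogen-bond donor and the leaving group has one. With the core held constant, the earlier 4-(trifluoromethoxy)phenyl group can now also be compared directly with 3,4-dimethoxyphenyl, and the result is a 1.2-fold lower number from compound 2 to compound 4 (0.09 log units; within the scatter), which shows that compounds 2, 3 and 4 cannot be told apart by this substituent. For the compounds shown here, compound 4 also provides the first comparison with the 3,4-dimethoxyphenyl group held constant, and a 1.2-fold higher number from compound 1 to compound 4 (0.09 log units; within the scatter) shows that 4-hydroxy-1H-benzimidazol-2-yl in place of 5-methyl-1H-benzimidazol-2-yl likewise leaves the number within the scatter.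

The compounds shown leave open whether an amine or a carboxylic acid at this position, on an aromatic carbon para to a large group, would give a step beyond the scatter. No measurement is available that could account for the closeness of these numbers.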